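The source may report more compounds than this note shows. Statements on the series, on what has been measured and on what is new or still open speak of the compounds shown alone.

Measured compounds:
compound 1, `CCN(CC)S(=O)(=O)c1ccc(S(=O)(=O)N2CCC[C@@H](C(=O)N[C@H]3CC[C@H](OC)CC3)C2)cc1`, in a functional assay on MIA PaCa-2 cells (Homo sapiens) for inhibition, read by MTT assay, with a stated time of 7 days (on this read-out higher numbers stand for weaker inhibition and lower numbers for stronger inhibition), compound 1 gives 1350 nM
compound 2, `CCN(CC)S(=O)(=O)c1ccc(S(=O)(=O)N2CCC[C@@H](C(=O)N3CCC(OC)CC3)C2)cc1`, compound 2 gives 140 nM
compound 3, `CN(C)S(=O)(=O)c1ccc(S(=O)(=O)N2CCC[C@@H](C(=O)N3CCC(F)(F)CC3)C2)cc1`, compound 3 gives 118 nM

Compound 3 has the lowest of the three numbers, but its gap to compound 2 is within the scatter, so the two cannot be ranked against each other; compound 1 stands furthest away, beyond the scatter. Going by the values given here, the only single-point step among the measured compounds is a 9.6-fold lower number from compound 1 to compound 2 (0.98 log units; beyond the scatter), which concerns the amide end of the shared core and not the sulfamoyl amine.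

Compound 4, `CCN(CC)S(=O)(=O)c1ccc(S(=O)(=O)N2CCC[C@@H](C(=O)N3CCC(F)(F)CC3)C2)cc1`, differs from compound 3 by diethylamino in place of dimethylamino on a sulfonyl sulfur. Among the compounds with values here, no measured pair isolates this exchange: compounds 1 and 2 carry the diethylamino group and compound 3 the dimethylamino group, but compound 2 and compound 3 also differ at the amide, and their values are within the scatter of each other. There is therefore no evidence that the exchange shifts the number beyond the scatter in either direction. Compound 4 is accordingly expected to land close to compound 3, with a step of about a 1.1-fold higher number from compound 3 to compound 4 (0.04 log units; within the scatter), giving an estimate of 130 nM, with a range from 50 nM to 350 nM.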

Compound 4, half-maximal inhibitory concentration: 16 nM
For compound 4 the middle estimate is 8.1-fold (0.91 log units) above the measured one; measured number outside the range, below it.
By their numbers in this assay, from the lowest: compound 4; then compounds 3 and 2 (each within the scatter of the next); then compound 1.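

In this assay, going by these compounds alone, the sulfonyl sulfur proves to be a position that matters: with the 4,4-difluoropiperidin-1-yl amide held fixed, diethylamino in place of dimethylamino gives a 7.4-fold lower number from compound 3 to compound 4 (0.87 log units; beyond the scatter) and thereby isolates this exchange for the first time. With diethylamino held fixed, the amide also gains two new readings, with 4,4-difluoropiperidin-1-yl in place of 4-methoxypiperidin-1-yl giving an 8.8-fold lower number from compound 2 to compound 4 (0.94 log units; beyond the scatter) and with 4,4-difluoropiperidin-1-yl in place of (4-methoxycyclohexyl)amino giving an 84-fold lower number from compound 1 to compound 4 (1.93 log units; beyond the scatter) and showing that the closeness of compound 2 and compound 3 concealed two single changes that pull in opposite directions. No measurement shown accounts for the size of these steps.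

As far as these compounds go, the diethylamino step rests on this one pair, so whether it keeps its size with a 4-methoxypiperidin-1-yl amide or any other amide remains open. From the compounds shown here alone, it also remains open how a longer chain such as dipropylamino, or a cyclic amine such as pyrrolidin-1-yl, would behave on the same sulfonyl sulfur.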